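Swapping a Methoxy for a Methylpiperazine on a Shared Core

The compounds below may be only part of what the source reports. "The series", "measured", "known", "first", "only" and "open" are said of these compounds alone.

Measured compounds:
compound 1 `Nc1c2c(=O)[nH]c(-c3ccccc3)cc2nn1-c1ccccc1`: -2%
compound 2 `COc1ccc(-c2cc3nn(-c4ccccc4)c(N)c3c(=O)[nH]2)cc1`: 16%

In an assay on isolated protein for inhibition of RAC-alpha serine/threonine-protein kinase (Homo sapiens), read by mobility shift assay, tested at 30 uM (on this read-out higher numbers stand for more inhibition at the one concentration tested (going by the name of the read-out) and lower numbers for less inhibition), compound 1 gives -2% and compound 2 gives 16%. Compound 2 therefore stands highest of the two numbers, and its nearest neighbour is compound 1, with a step of a number 18 percentage points higher from compound 1 to compound 2 (beyond the scatter). That step came from a methoxy in place of hydrogen on an aromatic carbon.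

Compound 3 `CN1CCN(c2ccc(-c3cc4nn(-c5ccccc5)c(N)c4c(=O)[nH]3)cc2)CC1` has not yet been measured in this assay. It differs from compound 2 in one place: 4-methylpiperazin-1-yl in place of methoxy on an aromatic carbon

For the measured compounds named here, only one measured step bears on this change, and only loosely: the step from compound 1 to compound 2 shows that placing a group on this aromatic carbon moved this assay by a number 18 percentage points higher from compound 1 to compound 2 (beyond the scatter), a modest shift. Going by the values given here, no measured pair shows a methoxy replaced by a 4-methylpiperazin-1-yl, so the direction of the new step is uncertain. A modest rise is expected, of about a number 9 percentage points higher from compound 2 to compound 3 (within the scatter), though a result within the scatter of compound 2 would not surprise. Compound 3 is estimated to give 25%, within a range from 5% to 50%.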

Compound 3, a percentage reported as inhibition, at one concentration (the size of the read-out at that concentration, not a potency): 3%
Beside the measured number, compound 3's estimate is 22 percentage points above it; measured number below the stated range.
By their numbers in this assay, from the lowest: compounds 1 and 3 (each within the scatter of the next); then compound 2.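

In this assay this aromatic carbon, para to a large group, does not reward every added group in the same way: replacing methoxy with 4-methylpiperazin-1-yl gives a number 13 percentage points lower from compound 2 to compound 3 (beyond the scatter), so the gain seen with methoxy does not carry over to this larger group. Set against the parent with plain hydrogen at this carbon, the same group gives a number 5 percentage points higher from compound 1 to compound 3 (within the scatter), which means that in this assay the 4-methylpiperazin-1-yl group cannot be told apart from hydrogen, and so far methoxy is the only group here that lifts the number beyond the scatter. Nothing measured here explains why the two groups differ.

The compounds shown leave open whether the gain belongs to methoxy alone or would also appear with a small group such as hydroxyl, ethoxy or dimethylamino, or with a ring such as morpholine, on this same carbon. They also leave open whether a group on the other phenyl ring, the one on the ring nitrogen of the shared core, would move the number at all.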